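A few compounds are considered here, and "the series" means these few. Any claim that something is new, unique, unknown or untested is made for them only; others in the source may bear on it.

Measured compounds in a functional assay on the whole organism (strain Sprague-Dawley) for inhibition, with Rattus norvegicus as the target; a higher number here means that more compound is needed for the effect, a lower number that less compound is needed:
compound 1, `O=c1c(-c2nn[nH]n2)c[nH]c2ccccc12`, 1.25 mg/kg
compound 2, `CSc1cccc2c(=O)c(-c3nn[nH]n3)c[nH]c12`, 10 mg/kg

Among the compounds with values here, compound 2 stands highest of the two numbers, with compound 1 as its only and nearest neighbour. Compound 3 `CC(C)Oc1cccc2c(=O)c(-c3nn[nH]n3)c[nH]c12` differs from compound 2 by isopropoxy in place of methylsulfanyl on an aromatic carbon. Within the data shown here, the one measured step that bears on this position is an 8.0-fold higher number from compound 1 to compound 2 (0.90 log units; beyond the scatter), which shows that a substituent on this aromatic carbon raised the number. Among the measured compounds shown here, no measured pair exchanges one substituent for another there, so the direction is uncertain; compound 3 is expected to stay close to compound 2, with a 1.3-fold lower number from compound 2 to compound 3 (0.10 log units; within the scatter). The estimate for compound 3 is 8 mg/kg, expected to fall between 2 mg/kg and 30 mg/kg.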

Compound 3, minimum effective dose: 0.078 mg/kg
Compound 3: the middle estimate sits 100-fold (2.01 log units) above what was measured, and the stated range ends above it.
By their numbers in this assay, from the lowest: compound 3; then compound 1; then compound 2.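

In this assay, within the data shown here, the exchange on this aromatic carbon matters far more than the earlier compounds suggested (a 130-fold lower number from compound 2 to compound 3 (2.11 log units; beyond the scatter)). A substituent here need not raise the number, as isopropoxy gives a lower number than hydrogen (a 16-fold lower number from compound 1 to compound 3 (1.20 log units; beyond the scatter)), so the direction depends on the group and not merely on the position being filled. Nothing given here explains why these two groups differ so widely. The compounds shown leave open whether methoxy, a longer alkoxy chain or an amine at this position would follow isopropoxy or methylsulfanyl.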